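Swapping 3-fluorophenyl for 4-fluorophenyl on a shared core

The source may hold more compounds than are shown below. What is called first, only, known or untested is meant among the compounds shown, and "the series" means these compounds.

Going by the values given here, four closely related compounds are in view here, but only one has a number so far. In a functional assay on HeLa cells (Homo sapiens) for cytotoxicity, read by WST assay, with a stated time of 48 h (on this read-out lower numbers stand for an effect already at smaller amounts and higher numbers for an effect only at larger amounts of compound), compound 1 (`O=C1OC[C@H](Cc2ccccc2)[C@H]1Cc1ccc(F)c(F)c1`) has the entry "not determined" (no result reported), and compound 2 (`Cc1ccccc1C[C@H]1COC(=O)[C@@H]1Cc1ccc(Cl)c(Cl)c1`) has the same entry, "not determined" (no result reported). Compound 3 (`O=C1OC[C@H](Cc2cccc(F)c2)[C@H]1Cc1ccc(Cl)c(Cl)c1`) gives 20000 nM, so it stands alone and cannot yet be ranked against any other compound.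

Compound 4 (`O=C1OC[C@H](Cc2ccc(F)cc2)[C@H]1Cc1ccc(Cl)c(Cl)c1`) has not been measured. Its difference from compound 3 is small: 4-fluorophenyl in place of 3-fluorophenyl on a saturated chain carbon bound to a saturated ring carbon. In words, it carries 4-fluorophenyl in place of 3-fluorophenyl on a saturated chain carbon bound to a saturated ring carbon, and the two compounds have the same atoms, joined differently.

Among the compounds with values here, no measured pair shows how large such a change can be in this assay. The expected result is therefore no change at the digits printed from compound 3 to compound 4 (within the scatter), an estimated step with no favoured direction and no size beyond the usual scatter. This expectation rests only on compound 3 at 20000 nM. The estimated value for compound 4 is 20000 nM, with an expected range from 7000 nM to 50000 nM.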

Compound 4, half-maximal effective concentration: 19000 nM
Compound 4: the middle estimate sits 1.1-fold (0.02 log units) above what was measured; measured number inside the range.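

In this assay, 4-fluorophenyl in place of 3-fluorophenyl on a saturated chain carbon bound to a saturated ring carbon gives a 1.1-fold lower number from compound 3 to compound 4 (0.02 log units; within the scatter). Going by these compounds alone, this is the first comparison available at this position, and it shows that this particular swap of one fluorophenyl group for the other leaves the two compounds indistinguishable on this read-out. No measurement at hand offers an explanation for this result.

The compounds shown leave open whether a different group in this place, such as an amine or a longer chain in place of the fluorophenyl group, would move the number at all. A single pair also cannot tell whether this swap would give an equally small step on another core.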